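Trimming the Carbamate: From Compound 3 to Compound 4

The source may hold more compounds than are shown below. What is called first, only, known or untested is meant among the compounds shown, and "the series" means these compounds.

Compound 3 `Cc1cc(NC(=O)OC(C)(C)C)nn1Cc1cc(Cl)ccc1OCC(C)C` carries a tert-butoxycarbonyl amino group on the shared core. In an assay on CHO-K1 cells for displacement of a labelled ligand from prostaglandin E2 receptor EP1 subtype (Homo sapiens) (a higher number here means a weaker inhibitor, a lower number a stronger inhibitor), compound 3 gives 31.6 nM, level with compound 2 `Cc1cc(NC(=O)C2CCCCC2)nn1Cc1cc(Cl)ccc1OCC(C)C`, which gives 31.6 nM in this assay; together they hold the lowest of the three numbers, while compound 1 `Cc1cc(C(=O)NN2CCOCC2)nn1Cc1cc(Cl)ccc1OCC(C)C` gives 251 nM. Compound 4 `Cc1cc(NC(=O)OC(C)C)nn1Cc1cc(Cl)ccc1OCC(C)C` differs from compound 3 by hydrogen in place of methyl on a saturated chain carbon bound to an oxygen next to a carbonyl group and two saturated chain carbons. Among the compounds with values here, the steps that bear on it are no change at the digits printed from compound 2 to compound 3 (within the scatter), and, from a different change, a 7.9-fold lower number from compound 1 to compound 2 (0.90 log units; beyond the scatter) and a 7.9-fold lower number from compound 1 to compound 3 (0.90 log units; beyond the scatter). The step between compound 2 and compound 3 exchanged a larger group on the carbonyl carbon without effect. Compound 4 is therefore expected to move little in this assay: a 1.4-fold higher number from compound 3 to compound 4 (0.15 log units; within the scatter). Compound 4 is estimated at 45 nM, within 15 nM to 140 nM.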

Compound 4, half-maximal inhibitory concentration: 50.1 nM
Beside the measured number, compound 4's estimate is 1.1-fold (0.05 log units) below it; measured number inside the range.
By their numbers in this assay, from the lowest: compounds 2, 3 and 4 (each within the scatter of the next); then compound 1.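

Going from tert-butoxy to isopropoxy on the carbonyl carbon leaves the number within the scatter in this assay (a 1.6-fold higher number from compound 3 to compound 4 (0.20 log units; within the scatter)). Isopropoxy in place of cyclohexyl on the carbonyl carbon also stays within the scatter (a 1.6-fold higher number from compound 2 to compound 4 (0.20 log units; within the scatter)). The separation from the compound with the (morpholin-4-yl)carbamoyl group remains beyond the scatter (a 5.0-fold lower number from compound 1 to compound 4 (0.70 log units; beyond the scatter)), so this position accepts the loss of a methyl without losing that difference. As far as these compounds go, whether ethoxy or methoxy on the same carbonyl carbon would hold the number, and what a free amine on the aromatic carbon would do, remains open. No measurement here accounts for these steps.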